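Azetidine substituent change and expected liver microsome clearance

The source may report more compounds than this note shows. Statements on the series, on what has been measured and on what is new or still open speak of the compounds shown alone.

Compound 1 `CC(C)n1nc(N)c2cnc(Nc3ccnc(-c4cnn(S(=O)(=O)C5CC5)c4)n3)cc21`: 13 mL/min/kg
Compound 2 `CC(C)n1nc(N2CC(CO)C2)c2cnc(Nc3ccnc(-c4cnn(S(=O)(=O)C5CC5)c4)n3)cc21`: 10 mL/min/kg

Within the data shown here, in an ADME assay on microsomes from liver (Homo sapiens) for pharmacokinetics (a higher number here means faster removal of the compound, a lower number slower removal), compound 2 stands alongside compound 1 on the two numbers measured so far, the step of a 1.3-fold lower number from compound 1 to compound 2 (0.11 log units; within the scatter) lying within the scatter. Compound 3 `CC(C)n1nc(N2CC(C(C)(C)O)C2)c2cnc(Nc3ccnc(-c4cnn(S(=O)(=O)C5CC5)c4)n3)cc21` differs from compound 2 by 1-hydroxy-1-methylethyl in place of hydroxymethyl on a saturated ring carbon. Among the measured compounds shown here, the single measured step concerns a different part of the shared core and was itself small, so no step bears directly on this change. Compound 3 is therefore expected to give about 10 mL/min/kg, with an estimated range from 6 mL/min/kg to 17 mL/min/kg. The expected step is no change at the digits printed from compound 2 to compound 3 (within the scatter), within the scatter.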

Compound 3, clearance: 8.9 mL/min/kg
Beside the measured number, compound 3's estimate is 1.1-fold (0.05 log units) above it; the measured number falls inside the stated range.
By their numbers in this assay, from the lowest: compounds 3, 2 and 1 (each within the scatter of the next).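

At the saturated ring carbon of the four-membered ring, 1-hydroxy-1-methylethyl in place of hydroxymethyl gives in this assay the step of a 1.1-fold lower number from compound 2 to compound 3 (0.05 log units; within the scatter) and so the larger group leaves the number within the scatter at this position. Set against the amino group on the aromatic carbon, 3-(1-hydroxy-1-methylethyl)azetidin-1-yl gives a 1.5-fold lower number from compound 1 to compound 3 (0.16 log units; within the scatter) and this step too stays within the scatter. No evidence here accounts for these numbers.
On these data alone, it remains open whether a carboxylic acid or an amine on this ring carbon would also stay within the scatter of compound 2.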